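A Bromophenyl Arm in Place of a Methylphenyl Arm

A few compounds are considered here, and "the series" means these few. Any claim that something is new, unique, unknown or untested is made for them only; others in the source may bear on it.

Three measured compounds share one core and differ only on one outer aromatic ring. Compound 1 `O=C1/C(=C/c2ccccc2)CCC/C1=C\c1ccc(Cl)cc1` carries a chloro group there, compound 2 `O=C1/C(=C/c2ccccc2)CCC/C1=C\c1ccc(Br)cc1` a bromo group, and compound 3 `Cc1ccc(/C=C2\CCC/C(=C\c3ccccc3)C2=O)cc1` a methyl group. In an assay on isolated protein for inhibition of Alpha glucosidase (Homo sapiens), with stated times of 5 min and 15 min, tested at 50 uM (on this read-out lower numbers stand for less inhibition and higher numbers for more inhibition at the one concentration tested (going by the name of the read-out)), compound 1 gives 27.6%, compound 2 gives 29.1%, and compound 3 gives 34.1%. Compound 3 holds the highest of the three numbers, but a number 6.5 percentage points higher from compound 1 to compound 3 (within the scatter) and a number 5 percentage points higher from compound 2 to compound 3 (within the scatter) are both within the scatter, as is a number 1.5 percentage points higher from compound 1 to compound 2 (within the scatter), so the three compounds cannot be told apart on these data.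

Compound 4 `O=C1/C(=C/c2ccccc2)CCC/C1=C\c1ccccc1Br` differs from compound 3 by 2-bromophenyl in place of 4-methylphenyl on a double-bonded chain carbon bound to a double-bonded ring carbon. Within the data shown here, no measured step matches this change: each measured step swaps one group for another at the same place on the ring, while here the group also moves. The three measured steps were all small, so the working expectation is a step of a number 5.1 percentage points lower from compound 3 to compound 4 (within the scatter), not beyond the scatter, though the data do not speak directly to a bromo group in this new place. Compound 4 is estimated to give 29%, within 14% to 44%, in this assay.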

Compound 4, a percentage reported as inhibition, at one concentration (the size of the read-out at that concentration, not a potency): 46.8%
Beside the measured number, compound 4's estimate is 17.8 percentage points below it; the whole stated range lies below it.
By their numbers in this assay, from the lowest: compounds 1, 2 and 3 (each within the scatter of the next); then compound 4.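

Every earlier step kept its group at the same place on the ring and stayed within the scatter, whereas in this assay the 2-bromophenyl arm stands apart from both the 4-methylphenyl arm (a number 12.7 percentage points higher from compound 3 to compound 4 (beyond the scatter)) and the 4-chlorophenyl arm (a number 19.2 percentage points higher from compound 1 to compound 4 (beyond the scatter)). Among these compounds, the most telling comparison keeps the bromo group and changes only where it sits, 2-bromophenyl in place of 4-bromophenyl (a number 17.7 percentage points higher from compound 2 to compound 4 (beyond the scatter)), so on this arm the place of the group matters in a way that the choice among chloro, bromo and methyl did not show in the earlier compounds. Nothing on hand explains this difference.

The compounds shown leave open whether a 2-chlorophenyl or 2-methylphenyl arm would match the 2-bromophenyl arm, which would show whether the gain belongs to the bromo group or to that place on the ring in general. They also leave open what a hydroxyl group, an amine or a carboxylic acid would do on this ring, and whether the same change would carry over to the other outer ring.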